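Trifluoromethyl for Methyl on a Benzyl Ether Chromone

A few compounds are considered here, and "the series" means these few. Any claim that something is new, unique, unknown or untested is made for them only; others in the source may bear on it.

Compound 2 `Cc1cccc(CSc2ccc3c(C)cc(=O)oc3c2)c1` carries a methyl on the benzylthio ring, and in a functional assay on DU-145 cells (Homo sapiens) for antiproliferative activity, read by sulforhodamine B assay, with a stated time of 72 h (on this read-out lower numbers stand for stronger inhibition of growth and higher numbers for weaker inhibition of growth), compound 2 gives only a limit, > 33700 nM. Compound 1 `Cc1cc(=O)oc2cc(SCc3cccc(C(F)(F)F)c3)ccc12` is its trifluoromethyl counterpart, and in this assay compound 1 likewise gives only a limit, > 28500 nM. The change between them is trifluoromethyl in place of methyl on an aromatic carbon, and its step that the two limits leave unreadable from compound 2 to compound 1 cannot be read because the limit of > 33700 nM in this assay, at which 1 of the 3 values shown sits, and the limit of > 28500 nM in this assay, at which 1 of the 3 values shown sits, both stop at the edge of the assay. Compound 3 `CCc1cc(=O)c2ccc(OCc3cccc(C)c3)c(C)c2o1` has a different core, a benzyl ether on a chromone; the difference between the two cores is not broken down here. In this assay, for the measured compounds named here, compound 3 gives 24100 nM, the only number among the three.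

Compound 4 `CCc1cc(=O)c2ccc(OCc3cccc(C(F)(F)F)c3)c(C)c2o1` differs from compound 3 by trifluoromethyl in place of methyl on an aromatic carbon, the same change as from compound 2 to compound 1. With the measured instance unreadable, only a small step is expected, a 1.1-fold higher number from compound 3 to compound 4 (0.03 log units; within the scatter). Compound 4 is therefore estimated at 26000 nM in this assay, between 9000 nM and 75000 nM.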

Compound 4, concentration for 50% growth inhibition: > 27600 nM
Compound 4 ended at the assay's limit (the forecaster's own chance of this, stated with the estimate: 35%); middle value at least 1.0-fold (0.02 log units) from the limit.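

In this assay, on the core of compound 3, trifluoromethyl in place of methyl on an aromatic carbon gives an at least 1.1-fold higher number from compound 3 to compound 4 (0.05 log units; that floor lies within the scatter). Compound 4 stands at a limit of the assay and not at a number: the limit of > 27600 nM in this assay, at which 1 of the 4 values shown sits. The step therefore has only a floor, and the step on the core of compound 1 cannot be read at all, so there are no two sizes to set side by side, and the data show neither that the change carries over from one core to the other nor that it does not.

All four compounds carry either methyl or trifluoromethyl at this place on the aromatic ring, which leaves open what an amine, a carboxylic acid or a longer chain would give there. From the compounds shown here alone, it also remains open whether any such group would bring the core of compound 1 to a readable number, and whether that number would then follow the core of compound 3.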